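Sulfanyl to sulfonyl on the chain carbon of compound 3

The compounds below may be only part of what the source reports. "The series", "measured", "known", "first", "only" and "open" are said of these compounds alone.

Measured compounds:
compound 1 `O=C(/C(=C\c1ccc(I)cc1)S(=O)(=O)c1ccc(Br)cc1)c1ccc(Br)cc1`: 1000 nM
compound 2 `O=C(/C(=C\c1ccc(Cl)c([N+](=O)[O-])c1)S(=O)(=O)c1ccc(Br)cc1)c1ccc(Br)cc1`: 10000 nM
compound 3 `O=C(/C(=C\c1ccc(Br)c([N+](=O)[O-])c1)Sc1ccc(Br)cc1)c1ccc(Br)cc1`: 1000 nM

In a functional assay on DU-145 cells (Homo sapiens) for inhibition, read by trypan blue exclusion, with a stated time of 96 h (on this read-out lower numbers stand for stronger inhibition of growth and higher numbers for weaker inhibition of growth), compound 3 sits level with compound 1 at the digits shown; together these two are the lowest numbers of the three, and compound 2 stands a clear step higher than both. For the measured compounds named here, the only single-site step measured so far is a 10-fold higher number from compound 1 to compound 2 (1.00 log units; beyond the scatter), which concerns the aryl ring on the chain carbon and not the sulfur linker. Going by the values given here, compound 2 and compound 3 differ in two places at once, so their pair shows only that the sulfonyl member with the nitro-bearing ring gives the higher number.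

Compound 4 `O=C(/C(=C\c1ccc(Br)c([N+](=O)[O-])c1)S(=O)(=O)c1ccc(Br)cc1)c1ccc(Br)cc1` is not yet measured. It differs from compound 3 by (4-bromophenyl)sulfonyl in place of (4-bromophenyl)sulfanyl on a double-bonded chain carbon bound to a carbonyl carbon and a double-bonded chain carbon. Among the compounds with values here, no measured step covers this change directly. Compound 4 shares its sulfonyl linker with compound 2, whose number is the highest of the set, while compound 3 with its sulfanyl linker gives 1000 nM. On that indirect footing a modest rise in this assay is expected for compound 4, that is a 3.0-fold higher number from compound 3 to compound 4 (0.48 log units; beyond the scatter), though a result within the scatter of compound 3 cannot be excluded. Compound 4 is estimated at 3000 nM, between 1000 nM and 12000 nM.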

Compound 4, concentration for 50% growth inhibition: 10000 nM
Compound 4: middle estimate off by 3.3-fold (0.52 log units), on the low side; the measured number falls inside the stated range.
By their numbers in this assay, from the lowest: compounds 1 and 3 (each within the scatter of the next); then compounds 2 and 4 (each within the scatter of the next).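

In this assay, for the compounds shown here, the step of a 10-fold higher number from compound 3 to compound 4 (1.00 log units; beyond the scatter) is the first direct reading of this position: with the 4-bromo-3-nitrophenyl group held fixed, (4-bromophenyl)sulfonyl in place of (4-bromophenyl)sulfanyl on the chain carbon alone carries a change beyond the scatter. Among the sulfonyl compounds, the halogen on the nitro-bearing ring does not register, as bromo in place of chloro gives no change at the digits printed from compound 2 to compound 4 (within the scatter) and the 4-bromo-3-nitrophenyl group in place of 4-iodophenyl gives a 10-fold higher number from compound 1 to compound 4 (1.00 log units; beyond the scatter) in line with the earlier 10-fold higher number from compound 1 to compound 2 (1.00 log units; beyond the scatter) for the chloro counterpart. No supporting data on hand explain why the sulfonyl linker gives the higher number.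

The compounds shown leave open whether the sulfanyl-to-sulfonyl step keeps its size with 4-iodophenyl on the chain carbon, so the step rests on a single pair, and how a sulfinyl or a methylene linker would read at this place. They also leave open how an amine or a carboxylic acid in place of the nitro group would read on this ring.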